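The source may report more compounds than this note shows. Statements on the series, on what has been measured and on what is new or still open speak of the compounds shown alone.

Measured so far in a functional assay on CHO cells for agonist activity at Free fatty acid receptor 1 (Homo sapiens); a lower number here means that less compound is needed, a higher number that more compound is needed for the effect:
- compound 1 `O=C(O)c1ccc(NCc2cccc(Oc3ccccc3)c2)cc1`: limit < 10000 nM
- compound 2 `Cc1nc(-c2ccc(C(F)(F)F)cc2)sc1CNc1ccc(CCCC(=O)O)cc1`: limit < 10000 nM
- compound 3 `O=C(O)COc1ccc(NCc2cccc(Oc3ccccc3)c2)cc1`: compound 3 gives 2040 nM.

The value of compound 1 in this assay is a limit of the assay, not a number. For compound 2 the value is likewise a limit. Among the measured compounds shown here, compound 3 is therefore the only compound of the three with a number in this assay. The step that the limit leaves unreadable from compound 1 to compound 3 cannot be sized, since the limit of < 10000 nM in this assay, at which 2 of the 3 values shown sit, hides its start.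

Compound 4 `CC(CC(=O)O)c1ccc(NCc2cccc(Oc3ccccc3)c2)cc1` is not yet measured; it differs from compound 3 by 1-(carboxymethyl)ethyl in place of carboxymethoxy on an aromatic carbon. No measured step bears on this change, and the one step shown is unreadable. The size of the step from compound 3 to compound 4 in this assay is thus expected only loosely, as a 2.6-fold lower number from compound 3 to compound 4 (0.41 log units; beyond the scatter), with no direction set by the data. Compound 4 is estimated at 800 nM, within 150 nM to 4000 nM.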

Compound 4, half-maximal effective concentration: 126 nM
Beside the measured number, compound 4's estimate is 6.3-fold (0.80 log units) above it, outside the stated range (below it).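

In this assay, among the compounds shown here, 1-(carboxymethyl)ethyl in place of carboxymethoxy on the aromatic carbon para to a large group gives a 16-fold lower number from compound 3 to compound 4 (1.21 log units; beyond the scatter), the first step that can be sized. The side chain on this carbon therefore strongly affects the number, even with the carboxylic acid present in both compounds. The steps from compound 1 cannot be read: the limit of < 10000 nM in this assay, at which 2 of the 4 values shown sit.

Open, going by these compounds, is whether the methyl branch or the exchange of oxygen for carbon carries the step; a 2-carboxyethyl chain on this carbon would separate the two. Also open, on these data alone, is how a tetrazole in place of the carboxylic acid would read.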